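An ethoxy group on the benzyl arm of compound 2

The source may hold more compounds than are shown below. What is called first, only, known or untested is meant among the compounds shown, and "the series" means these compounds.

Compound 1 `CCc1ccccc1N(CC(=O)OCc1ccc(OC)cc1)S(=O)(=O)c1ccc(C)cc1` gives 63 nM; 63.1 nM (2 entries) in an assay on CHO cells for displacement of a labelled ligand from prostaglandin E2 receptor EP1 subtype (Homo sapiens); on this read-out lower numbers stand for stronger inhibition and higher numbers for weaker inhibition. Among the measured compounds shown here, compound 2 `CCc1ccccc1N(Cc1nnc(Cc2ccccc2)o1)S(=O)(=O)c1ccc(C)cc1` gives 1000 nM in this assay, the only number it shows among several entries. Compound 3 `CCc1ccccc1N(Cc1nnc(Cc2ccc(OC)cc2)o1)S(=O)(=O)c1ccc(C)cc1` gives 126 nM; 126 nM (2 entries) in this assay, and the values of compound 2 and compound 3 lie well apart. Compound 4 `CCOc1ccc(Cc2nnc(CN(c3ccccc3CC)S(=O)(=O)c3ccc(C)cc3)o2)cc1` has not yet been measured; it differs from compound 2 by ethoxy in place of hydrogen on an aromatic carbon. For the measured compounds named here, no measured pair shows this exact change, so the step in this assay is expected to be a 5.0-fold lower number from compound 2 to compound 4 (0.70 log units; beyond the scatter), toward stronger inhibition. Compound 4 is therefore estimated at 200 nM, with a range from 60 nM to 700 nM.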

Compound 4, half-maximal inhibitory concentration: 126 nM
For compound 4 the middle estimate is 1.6-fold (0.20 log units) above the measured one, within the range that was stated.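

In this assay, ethoxy on the aromatic carbon para to a large group gives a 7.9-fold lower number from compound 2 to compound 4 (0.90 log units; beyond the scatter), so at this position a group larger than hydrogen goes with stronger inhibition. With methoxy at the same place compound 3 gives 126 nM; 126 nM (2 entries) and with ethoxy compound 4 gives 126 nM, so these values show no difference between the two groups. Nothing measured here accounts for the step. On these data alone, whether an amine, a carboxylic acid or a longer chain such as butoxy at this place would keep this level remains open, as does the outcome of ethoxy elsewhere on this ring.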